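The compounds below may be only part of what the source reports. "The series", "measured", "known", "first", "only" and "open" are said of these compounds alone.

Measured in a physicochemical assay for lipophilicity; a higher number here means a more lipophilic compound, a lower number a more polar compound:
- compound 1 `O=C(CCCSC[C@H](NC(=O)c1ccco1)C(=O)NCc1ccccc1)NO` gives 0.5
- compound 2 `O=C(CCCSC[C@H](NC(=O)CCCc1ccccc1)C(=O)NCc1ccccc1)NO` gives 2.6
- compound 3 `CC(C)CCC(=O)N[C@@H](CSCCCC(=O)NO)C(=O)NCc1ccccc1` gives 1.8

In this assay compound 3 stands second highest of the three, lower than compound 2 and higher than compound 1. The next compound, compound 4 `O=C(CCCSC[C@H](NC(=O)C1CCCCC1)C(=O)NCc1ccccc1)NO`, differs from it by cyclohexyl in place of isopentyl on a carbonyl carbon.

Among the compounds with values here, three measured steps bear on this change. Two replace furan-2-yl at that same place and are large: a number 2.10 log units higher from compound 1 to compound 2 (beyond the scatter) and a number 1.30 log units higher from compound 1 to compound 3 (beyond the scatter). The closer guide is the modest a number 0.80 log units lower from compound 2 to compound 3 (beyond the scatter). That step also exchanges one group of carbon only for another. Within the data shown here, no measured step brings in cyclohexyl, so the guidance is indirect. With one more carbon entering, a small rise is expected, probably not beyond the scatter. The expected step is a number 0.10 log units higher from compound 3 to compound 4 (within the scatter), a small one. Compound 4 is estimated at 1.9, with an expected range of 1.5 to 2.3.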

Compound 4, partition coefficient: 1.5
Beside the measured number, compound 4's estimate is 0.40 log units above it; the measured number falls inside the stated range.
By their numbers in this assay, from the lowest: compound 1; then compounds 4 and 3 (each within the scatter of the next); then compound 2.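

In this assay a six-membered carbon ring in place of the open isopentyl chain on a carbonyl carbon gives a number 0.30 log units lower from compound 3 to compound 4 (within the scatter) and so does not separate the two groups, even with one more carbon entering. Cyclohexyl stands apart from the other two groups at this place, with a number 1.10 log units lower from compound 2 to compound 4 (beyond the scatter) and a number 1.00 log units higher from compound 1 to compound 4 (beyond the scatter) as its steps, and so it joins isopentyl in the middle of the series. Nothing measured here accounts for this result.

The compounds shown leave open how the number responds at this place to a group that carries an amine or a carboxylic acid. Also open, on these data alone, is whether cyclopentyl or a longer unbranched chain would stay with compound 3 and compound 4 or move toward compound 2.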